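Anilino to pyrimidinylamino exchange on the shared core

The compounds below may be only part of what the source reports. "The series", "measured", "known", "first", "only" and "open" are said of these compounds alone.

Compound 2 `C[C@@H](Cn1ccc(-c2ccc(C#N)c(Cl)c2)n1)Nc1ccccc1` stands lowest of the two numbers in a functional assay on LNCaP cells (Homo sapiens) for antiproliferative activity, read by CCK-8 assay, with a stated time of 6 days (on this read-out lower numbers stand for stronger inhibition and higher numbers for weaker inhibition), where compound 2 gives 710 nM. Compound 1 `COC(=O)/C=C/C(=O)N[C@@H](C)Cn1ccc(-c2ccc(C#N)c(Cl)c2)n1` gives 2460 nM. For the measured compounds named here, the only measured step, a 3.5-fold lower number from compound 1 to compound 2 (0.54 log units; beyond the scatter), concerns a different exchange on the same amine nitrogen and does not cover the present change. Compound 3 `C[C@@H](Cn1ccc(-c2ccc(C#N)c(Cl)c2)n1)Nc1ncccn1` differs from compound 2 by pyrimidin-2-yl in place of phenyl on an amine nitrogen. Going by the values given here, no measured step addresses a carbon-only ring replaced by a ring with 2 hetero atoms at this place, so nothing beyond the scatter is expected in either direction. The estimated step is a 1.0-fold lower number from compound 2 to compound 3 (0.01 log units; within the scatter). Compound 3 is expected to give 700 nM, within 250 nM to 2000 nM.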

Compound 3, half-maximal inhibitory concentration: 1180 nM
Estimate against measurement, compound 3: 1.7-fold (0.23 log units) below, within the range that was stated.
By their numbers in this assay, from the lowest: compounds 2 and 3 (each within the scatter of the next); then compound 1.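

In this assay, pyrimidin-2-yl and phenyl on this amine nitrogen cannot be told apart (a 1.7-fold higher number from compound 2 to compound 3 (0.22 log units; within the scatter)), so the two ring nitrogens and their hydrogen-bond acceptors bring no change beyond the scatter. Pyrimidin-2-yl also compares with the (2-(methoxycarbonyl)ethenyl)carbonyl group of compound 1 much as phenyl does, though modestly (a 2.1-fold lower number from compound 1 to compound 3 (0.32 log units; beyond the scatter)). Nothing at hand bears on why these groups compare as they do.

Open, going by these compounds, is how pyridin-2-yl or a saturated ring such as piperidin-4-yl would read on this nitrogen. Also open, on these data alone, is whether a substituted phenyl, such as 4-methoxyphenyl, separates from the plain ring.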